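A few compounds are considered here, and "the series" means these few. Any claim that something is new, unique, unknown or untested is made for them only; others in the source may bear on it.

Measured in a functional assay on U-937 cells (Homo sapiens) for cytotoxicity, read by MTT assay, with a stated time of 72 h; on this read-out lower numbers stand for stronger inhibition and higher numbers for weaker inhibition:
- compound 1 `Cc1c(C)c2c(c(C)c1OC(=O)CCC(=O)NC1CC(C)(C)N([O])C(C)(C)C1)CC[C@@](C)(CCC[C@H](C)CCC[C@H](C)CCCC(C)C)O2`: 76000 nM
- compound 2 `CC1(C)CC(CNC(=O)CCC(=O)O)C(C)(C)N1[O]`: 282000 nM
- compound 3 `Cc1c(C)c2c(c(C)c1OC(=O)CCC(=O)NCC1CC(C)(C)N([O])C1(C)C)CCC(C)(C(=O)NCC1CC(C)(C)N([O])C1(C)C)O2`: 61000 nM

Compound 1 cannot be told apart from compound 3 in this assay, as their two values lie within the scatter of each other. Compound 2 has the higher number, beyond the scatter from both.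

Compound 4 `Cc1c(C)c2c(c(C)c1OC(=O)CCC(=O)NCC1CC(C)(C)N([O])C1(C)C)CC[C@@](C)(CCC[C@H](C)CCC[C@H](C)CCCC(C)C)O2` has not yet been measured. It keeps the core and long chain of compound 1, and the change is a group of 11 heavy atoms (9 carbon, 1 nitrogen, 1 oxygen; one five-membered non-aromatic ring with 1 hetero atom) in place of a group of 11 heavy atoms (9 carbon, 1 nitrogen, 1 oxygen; one six-membered non-aromatic ring with 1 hetero atom), on an amide-type nitrogen. The two have the same atoms, joined differently.

Going by the values given here, no measured pair isolates this change, so the evidence is indirect. Compound 3 carries the five-membered ring and gives 61000 nM, close to compound 1. Compound 2 also carries that ring and gives 282000 nM, so the ring alone does not fix the value, though compound 2 lacks the shared core. The expected step is a 1.1-fold lower number from compound 1 to compound 4 (0.04 log units; within the scatter), which means no change beyond the scatter. For compound 4 the estimated value is 70000 nM, with an expected range of 35000 nM to 150000 nM.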

Compound 4, half-maximal inhibitory concentration: 137000 nM
Compound 4: the middle estimate sits 2.0-fold (0.29 log units) below what was measured; low and high end bracket the measured number.
By their numbers in this assay, from the lowest: compounds 3, 1 and 4 (each within the scatter of the next, the first and the last beyond it); then compound 2.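

In this assay the ring change on the amide-type nitrogen can now be read directly, with the core and long chain held fixed: the five-membered non-aromatic ring in place of the six-membered non-aromatic ring gives a 1.8-fold higher number from compound 1 to compound 4 (0.26 log units; within the scatter) and so cannot be told apart from no change. Going by these compounds alone, at this position, then, the two rings of equal atom count read alike within the scatter, where the earlier compounds offered only indirect comparisons. Nothing further is available to account for the values.

The compounds shown leave open whether the same ring change reads alike on a core without the long chain. They also leave open what an open-chain alkyl group, a primary amine or a carboxylic acid would give on this amide-type nitrogen.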